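Methoxy for chloro on the benzyl arm of compound 1

The compounds below may be only part of what the source reports. "The series", "measured", "known", "first", "only" and "open" are said of these compounds alone.

Of the compounds shown here, three have been measured in an assay for binding affinity to Alpha-1A adrenergic receptor (Homo sapiens); a higher number here means a weaker inhibitor, a lower number a stronger inhibitor. Compound 1 `CN1CCC[C@@H]1Cn1nc(Cc2cccc(Cl)c2)c2ccccc2c1=O` gives 398 nM and stands second highest of the three numbers. Compound 2 `CN(C)CCn1nc(Cc2ccc(Cl)cc2)c2ccccc2c1=O` gives the lower number 158 nM, while compound 3 `CN(CCCCc1ccc(OCCCN2CCCCCC2)cc1)CCn1nc(Cc2ccc(Cl)cc2)c2ccccc2c1=O` gives the higher number 1580 nM; both gaps to compound 1 lie beyond the usual scatter. The compounds differ in more than one place, so no single change can be read from these pairs.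

Compound 4 `COc1ccc(Cc2nn(C[C@H]3CCCN3C)c(=O)c3ccccc23)cc1` is not yet measured. It departs from compound 1 by one change (4-methoxyphenyl in place of 3-chlorophenyl on a saturated chain carbon bound to an aromatic carbon). The chlorine leaves and a methoxy group arrives with one hydrogen-bond acceptor; the shared core and the chain bearing the basic amine stay as in compound 1. Among the compounds with values here, no measured pair isolates this change, so the expectation rests on compound 1 alone, with 398 nM as the anchor.

The step is expected to be small and toward a higher number, most likely not beyond the scatter, a 1.5-fold higher number from compound 1 to compound 4 (0.18 log units; within the scatter). For compound 4 the estimate in this assay is 600 nM, with a range from 200 nM to 1800 nM.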

Compound 4, inhibition constant: 126 nM
The estimate for compound 4 lay 4.8-fold (0.68 log units) above the measured number; the measured number lies below the stated range.
By their numbers in this assay, from the lowest: compounds 4 and 2 (each within the scatter of the next); then compound 1; then compound 3.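

In this assay, the benzyl arm of the shared core proves responsive to substitution: 4-methoxyphenyl in place of 3-chlorophenyl gives a step beyond the scatter (a 3.2-fold lower number from compound 1 to compound 4 (0.50 log units; beyond the scatter)). Within the data shown here, this is the first single change readable, and it runs toward the lower number. Substituent and ring number change together, however, so the step belongs to the whole exchange of 3-chlorophenyl for 4-methoxyphenyl, and the data offer no explanation for it.

The data do not separate the methoxy group from its ring number. 3-methoxyphenyl and unsubstituted phenyl on the same chain carbon are natural comparators. Also open, as far as these compounds go, is whether the step carries over when the amine chain of compound 1 is replaced by a dimethylaminoethyl chain.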